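Replacing a ring-bearing group with a short amide chain

The source may hold more compounds than are shown below. What is called first, only, known or untested is meant among the compounds shown, and "the series" means these compounds.

Of the compounds shown here, two of one shared core have been tested in an assay on VSM-A10 cells for antagonist activity at Endothelin-1 receptor (Rattus norvegicus); a higher number here means a weaker inhibitor, a lower number a stronger inhibitor. Compound 1, `Cc1noc(N(CC(=O)O)S(=O)(=O)c2ccc(N)cc2)c1C`, gives in this assay > 32000 nM, which is a limit of the measurement and not a number. Compound 2, `Cc1noc(NS(=O)(=O)c2ccc(N/C(S)=N/c3ccccc3)cc2)c1C`, gives in this assay 4100 nM, and this is the only real number shown; the other value is the limit of > 32000 nM in this assay, at which 1 of the 2 values shown sits. Compound 2 therefore stands alone as the single measured point.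

Compound 3, `Cc1noc(NS(=O)(=O)c2ccc(NC(=O)CN)cc2)c1C`, has not yet been measured. It differs from compound 2 in one place: a group of 4 heavy atoms (2 carbon, 1 nitrogen, 1 oxygen; no ring) in place of a group of 9 heavy atoms (7 carbon, 1 nitrogen, 1 sulfur; one six-membered aromatic ring of carbon only), on a nitrogen on an aromatic ring. In plain words, a group of 4 heavy atoms (2 carbon, 1 nitrogen, 1 oxygen; no ring) takes the place of a group of 9 heavy atoms (7 carbon, 1 nitrogen, 1 sulfur; one six-membered aromatic ring of carbon only), on a nitrogen on an aromatic ring. Within the data shown here, no measured pair shows the size of such a swap. Because compound 1 sits at the limit of > 32000 nM in this assay, at which 1 of the 2 values shown sits, the step of a 3.7-fold higher number from compound 2 to compound 3 (0.56 log units; beyond the scatter) is expected to run toward weaker inhibition, beyond the usual scatter. For compound 3 the estimate in this assay is 15000 nM, within 4000 nM to 60000 nM.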

Compound 3, half-maximal inhibitory concentration: 6500 nM
Compound 3: the middle estimate sits 2.3-fold (0.36 log units) above what was measured, within the range that was stated.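

Replacing the larger group on this nitrogen with the (aminomethyl)carbonyl group gives, in this assay, a 1.6-fold higher number from compound 2 to compound 3 (0.20 log units; within the scatter), so the two compounds cannot be told apart in this test. Among these compounds, this is the first direct comparison at this position, and it shows that, for this pair, the six-membered aromatic ring of carbon only and the sulfur of the group that leaves are not required to hold inhibition at this level: a group with no ring and fewer heavy atoms does as well, within the scatter. Nothing given here explains why the two groups match so closely, and a similar result does not mean that they act in the same way.

Going by these compounds, what a longer chain, or a carboxylic acid in place of the amine at the end of the (aminomethyl)carbonyl group, would do on this nitrogen remains open. On these data alone, it is also open whether a benzoyl group, which keeps the ring while using the same carbonyl link, would move the number beyond the scatter in either direction.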